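A few compounds are considered here, and "the series" means these few. Any claim that something is new, unique, unknown or untested is made for them only; others in the source may bear on it.

Measured compounds in a functional assay on cells for agonist activity at Glucose-dependent insulinotropic receptor (Homo sapiens), read by a luciferase reporter, with a stated time of 6 h; a lower number here means that less compound is needed, a higher number that more compound is needed for the effect:

compound 1 `CON(C)C(=O)c1ccc(-c2csc3c(OC4CCN(C(=O)OC(C)(C)C)CC4)ncnc23)cc1` — 64 nM
compound 2 `CON(C)C(=O)c1ccc(-c2csc3c(OC4CCN(C(=O)OC(C)(C)C)CC4)ncnc23)cc1F` — 57 nM
compound 3 `CON(C)C(=O)c1ccc(-c2ccc(OCC3CCN(C(=O)OC(C)(C)C)CC3)cn2)cc1` — 171 nM

Compound 1 and compound 2 share one core and differ only by fluoro in place of hydrogen on an aromatic carbon; the step of a 1.1-fold lower number from compound 1 to compound 2 (0.05 log units; within the scatter) is within the scatter, so the two values are read as the same. Compound 3 is built on a second core; the difference between the two cores is not broken down here. In this assay compound 3 gives 171 nM, the highest number of the three, and its gap to compound 1 and to compound 2 lies beyond the scatter in each case.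

Compound 4 `CON(C)C(=O)c1ccc(-c2ccc(OCC3CCN(C(=O)OC(C)(C)C)CC3)cn2)cc1F` is the unmeasured partner of compound 3. It differs from compound 3 by fluoro in place of hydrogen on an aromatic carbon, and the surroundings of the place are described in the same words as for the change from compound 1 to compound 2, so this is the same change made on the second core. For the measured compounds named here, there is only one earlier instance of it, and it left the number essentially unchanged. The step for compound 4 is expected to be a 1.1-fold lower number from compound 3 to compound 4 (0.04 log units; within the scatter), small, because the same change gave a 1.1-fold lower number from compound 1 to compound 2 (0.05 log units; within the scatter) on the first core. Compound 4 is therefore expected to give about 155 nM in this assay, most likely between 75 nM and 320 nM, close to the value of compound 3.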

Compound 4, half-maximal effective concentration: 73 nM
Compound 4: the middle estimate sits 2.1-fold (0.33 log units) above what was measured, outside the stated range (below it).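

In this assay the change of hydrogen to fluoro on an aromatic carbon, ortho to a methoxy(methyl)carbamoyl group, gives a 2.3-fold lower number from compound 3 to compound 4 (0.37 log units; beyond the scatter) on the core of compound 3, a modest step. The size of this step cannot be told apart from that of the earlier step, a 1.1-fold lower number from compound 1 to compound 2 (0.05 log units; within the scatter), once the spread of two such steps is allowed for: the same change on two cores in this assay, a 1.1-fold lower number (0.05 log units; within the scatter) from compound 1 to compound 2 and a 2.3-fold lower number (0.37 log units; beyond the scatter) from compound 3 to compound 4, 2.1-fold (0.32 log units) apart, within the scatter of two such steps. The two cores therefore give no sign that the change behaves differently from one to the other, but a single pair on each core does not show that the steps are equal in size, does not set a rule for any further core, and does not explain the step.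

From the compounds shown here alone, whether chloro, methyl or a nitrile at the same place would follow fluoro remains open, as does the outcome of replacing the methoxy(methyl)carbamoyl group itself with a simple amine or a carboxylic acid. Going by these compounds, the tert-butyl carbamate is common to all four compounds, so it also remains open whether the fluoro step would hold with a urea or a sulfonamide at that end of the molecule.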